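The source may report more compounds than this note shows. Statements on the series, on what has been measured and on what is new or still open speak of the compounds shown alone.

Three compounds on a shared core have numbers in a functional assay on HeLa cells (Homo sapiens) for antiproliferative activity, read by XTT assay, with a stated time of 72 h; a lower number here means a stronger inhibitor, a higher number a weaker inhibitor. Compound 1 `C=C(C)CC[C@]1(C)C2=CCC[C@](C)(C[C@H](O)c3ccoc3)[C@H]2CC[C@H]1C` gives 30200 nM, compound 2 `C=C(C)CC[C@]1(C)C2=CCC[C@](C)(C[C@@H](O)C3=CC(=O)OC3O)[C@H]2CC[C@H]1C` gives 5400 nM and compound 3 `C=C(C)CC[C@]1(C)C2=CCC[C@](C)(C[C@H](O)C3=CC(=O)OC3O)[C@H]2CC[C@H]1C` gives 4800 nM. Compound 3 thus sits level with compound 2, and both stand clear of compound 1.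

Compound 4 `C=C(C)CC[C@]1(C)C2=CCC[C@](C)(C[C@@H](O)c3ccoc3)[C@H]2CC[C@H]1C` is still unmeasured. Its change from compound 3 is a group of 7 heavy atoms (5 carbon, 2 oxygen; one five-membered aromatic ring with 1 hetero atom) in place of a group of 9 heavy atoms (5 carbon, 4 oxygen; one five-membered non-aromatic ring with 1 hetero atom), on a saturated chain carbon bound to a saturated ring carbon. The (furan-3-yl)(hydroxy)methyl group that enters also appears in compound 1, so two measured steps bear on it. The exchange of the five-membered aromatic ring for the non-aromatic one gave a 6.3-fold lower number from compound 1 to compound 3 (0.80 log units; beyond the scatter), and a 5.6-fold lower number from compound 1 to compound 2 (0.75 log units; beyond the scatter) was similar in size, both beyond the scatter. The stereocentre alone gave a 1.1-fold lower number from compound 2 to compound 3 (0.05 log units; within the scatter), within the scatter, so it adds no expected shift.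

Reversing the exchange seen with compound 1 should therefore give a modest move toward a higher number, a weaker inhibitor. The expected step is a 5.8-fold higher number from compound 3 to compound 4 (0.77 log units; beyond the scatter). Compound 4 is estimated at 28000 nM, with an expected range of 12000 nM to 65000 nM.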

Compound 4, half-maximal inhibitory concentration: 30200 nM
Beside the measured number, compound 4's estimate is 1.1-fold (0.03 log units) below it; the range from low to high includes it.
By their numbers in this assay, from the lowest: compounds 3 and 2 (each within the scatter of the next); then compounds 1 and 4 (each within the scatter of the next).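

In this assay, the drawn configuration at the saturated chain carbon bearing the hydroxyl makes no visible difference with the furan-3-yl group either, with no change at the digits printed from compound 1 to compound 4 (within the scatter), which extends what the non-aromatic ring pair had shown: the fact that compounds 1 and 4 differ only in the configuration as drawn. The furan-3-yl group now gives a 5.6-fold higher number from compound 2 to compound 4 (0.75 log units; beyond the scatter) with the configuration held the same, and a 6.3-fold higher number from compound 3 to compound 4 (0.80 log units; beyond the scatter) with the configuration changed as well. The ring exchange is therefore seen at both drawn configurations, at much the same size: the same change on two cores in this assay, a 6.3-fold lower number (0.80 log units; beyond the scatter) from compound 1 to compound 3 and a 5.6-fold lower number (0.75 log units; beyond the scatter) from compound 4 to compound 2, 1.1-fold (0.05 log units) apart, within the scatter of two such steps.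

As far as these compounds go, the ring hydroxyl and the carbonyl of the non-aromatic ring enter together in every step, and which of them carries the shift remains open. Also open, from the compounds shown here alone, is whether a carboxylic acid or an amide at this place would give a number like those of compound 2 and compound 3.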